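Replacing methyl with 4-methylphenyl on the sulfonyl sulfur

A few compounds are considered here, and "the series" means these few. Any claim that something is new, unique, unknown or untested is made for them only; others in the source may bear on it.

Compound 2 `CN(C)c1ccc(C2CC(c3ccc(-n4cncn4)cc3)=NN2S(C)(=O)=O)cc1` stands lowest of the two measured numbers: in a functional assay on NCI-H1975 cells (Homo sapiens) for inhibition, read by sulforhodamine B assay, tested at 10 uM (on this read-out higher numbers stand for more inhibition at the one concentration tested (going by the name of the read-out) and lower numbers for less inhibition), compound 2 gives -3.1%. Among the measured compounds shown here, its only measured neighbour is compound 1 `CN(C)c1ccc(C2CC(c3ccc(-n4cncn4)cc3)=NN2C(=O)c2ccc(C(F)(F)F)cc2)cc1`, which in this assay gives 11.5%; the step of a number 14.6 percentage points lower from compound 1 to compound 2 (beyond the scatter) traded a large aromatic group on the ring nitrogen for a small methylsulfonyl and lowered inhibition. Compound 3 `Cc1ccc(S(=O)(=O)N2N=C(c3ccc(-n4cncn4)cc3)CC2c2ccc(N(C)C)cc2)cc1` differs from compound 2 in one place: 4-methylphenyl in place of methyl on a sulfonyl sulfur. For the measured compounds named here, the only step that bears on it is the one from compound 1 to compound 2, where losing an aromatic ring at this position cost inhibition beyond the scatter. Restoring an aromatic ring, now on the sulfonyl sulfur, is therefore expected to raise inhibition modestly. Compound 3 is expected to show a step of a number 11.1 percentage points higher from compound 2 to compound 3 (beyond the scatter). Compound 3 is estimated at 8%, with a range from -8% to 25%.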

Compound 3, a percentage reported as inhibition, at one concentration (the size of the read-out at that concentration, not a potency): 20%
For compound 3 the middle estimate is 12 percentage points below the measured one; the range from low to high includes it.
By their numbers in this assay, from the lowest: compound 2; then compounds 1 and 3 (each within the scatter of the next).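

In this assay, 4-methylphenyl in place of methyl on the sulfonyl sulfur gives a number 23.1 percentage points higher from compound 2 to compound 3 (beyond the scatter) here, so the low number of compound 2 goes with the methylsulfonyl group and not with a sulfonyl link as such. With (4-methylphenyl)sulfonyl in place of (4-(trifluoromethyl)phenyl)carbonyl on the amine nitrogen in a ring, the result is a number 8.5 percentage points higher from compound 1 to compound 3 (within the scatter) and the two groups cannot be told apart, so in these compounds an aromatic ring serves on either link. Nothing measured here accounts for the gain on the sulfonyl sulfur.

Still open, from the compounds shown here alone, is whether the ring alone carries the gain or its methyl also contributes, which a plain phenyl or a 4-methoxyphenyl on the sulfur would test. A longer chain such as butyl would show whether a ring is needed at all.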